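From 4-fluorophenyl to 4-methylphenyl in compound 3

The source may report more compounds than this note shows. Statements on the series, on what has been measured and on what is new or still open speak of the compounds shown alone.

- Compound 1 `Cc1ccc(/C=C/C(=O)Nc2nnc(-c3ccccc3)s2)cc1` gives 1.23 ug/mL
- Compound 2 `O=C(/C=C/c1ccc(F)cc1)Nc1nnc(-c2ccc(Br)cc2)s1` gives 1.49 ug/mL

In a functional assay on MCF7 cells (Homo sapiens) for antiproliferative activity, read by MTT assay, with a stated time of 48 h (on this read-out higher numbers stand for weaker inhibition and lower numbers for stronger inhibition), compound 2 stands at 1.49 ug/mL, within the usual scatter of compound 1 at 1.23 ug/mL. Compound 3 `Cc1ccc(/C=C/C(=O)Nc2nnc(-c3ccc(Br)cc3)s2)cc1` is still unmeasured. Among the measured compounds shown here, it has methyl in place of fluoro on an aromatic carbon, para to a large group, as its only difference from compound 2 (methyl in place of fluoro on an aromatic carbon). For the measured compounds named here, no measured pair shows this exchange. The estimated step of a 1.1-fold lower number from compound 2 to compound 3 (0.03 log units; within the scatter) is therefore expected to stay within the scatter, with no favoured direction. For compound 3 the expected value is 1.4 ug/mL, with an estimated range of 0.7 ug/mL to 2.8 ug/mL.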

Compound 3, half-maximal inhibitory concentration: 1.32 ug/mL
Compound 3: middle estimate off by 1.1-fold (0.03 log units), on the high side; the measured number falls inside the stated range.
By their numbers in this assay, from the lowest: compounds 1, 3 and 2 (each within the scatter of the next).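

In this assay, among the compounds shown here, methyl in place of fluoro on an aromatic carbon, para to a large group, gives a 1.1-fold lower number from compound 2 to compound 3 (0.05 log units; within the scatter) and thus provides the first direct comparison of the two groups at this position, with no difference beyond the scatter. Bromo in place of hydrogen on an aromatic carbon gives a 1.1-fold higher number from compound 1 to compound 3 (0.03 log units; within the scatter) and also stays within the scatter. Nothing available gives a reason for either step.

As far as these compounds go, whether an amine or a carboxylic acid at the methyl position would stay within the scatter remains open. So does whether methoxy would.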